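Adding a Hydroxy Group to the Ethylamino Chain

The compounds below may be only part of what the source reports. "The series", "measured", "known", "first", "only" and "open" are said of these compounds alone.

For the measured compounds named here, in an assay on HeLa cells for displacement of a labelled ligand from 5-hydroxytryptamine receptor 6 (Homo sapiens) (a lower number here means a stronger inhibitor, a higher number a weaker inhibitor), compound 2 `CCNc1nc2ccccn2c(=N)c1S(=O)(=O)c1ccccc1` gives 2 nM, the lower of the two numbers measured so far. Compound 1 `C[S+]([O-])c1nc2ccccn2c(=N)c1S(=O)(=O)c1ccccc1` gives 250 nM in this assay, and the step of a 130-fold lower number from compound 1 to compound 2 (2.10 log units; beyond the scatter) replaced the whole group on that aromatic carbon. Compound 3 `N=c1c(S(=O)(=O)c2ccccc2)c(NCCO)nc2ccccn12` differs from compound 2 by hydroxy in place of hydrogen on a saturated chain carbon, two bonds along the chain from a nitrogen on an aromatic ring. That single measured step changes a different part of the molecule and does not bear on this chain, so no change beyond the scatter is expected. Compound 3 is therefore expected to give 3 nM, between 1 nM and 10 nM, a step of a 1.5-fold higher number from compound 2 to compound 3 (0.18 log units; within the scatter).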

Compound 3, half-maximal inhibitory concentration: 42 nM
Compound 3: the middle estimate sits 14-fold (1.15 log units) below what was measured, outside the stated range (above it).
By their numbers in this assay, from the lowest: compound 2; then compound 3; then compound 1.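

In this assay the ethylamino chain proves sensitive to one small change: hydroxy in place of hydrogen on the saturated chain carbon gives a 21-fold higher number from compound 2 to compound 3 (1.32 log units; beyond the scatter) and so gives back much of the gain. Yet (2-hydroxyethyl)amino still does better than the group it replaces on the aromatic carbon, with a 6.0-fold lower number from compound 1 to compound 3 (0.77 log units; beyond the scatter) left in its favour. The compounds shown leave open whether a methoxy group or an amine at that chain carbon would behave like hydroxy, and whether a longer chain such as propylamino would hold the low number. No measurement here speaks to what lies behind this change.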